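Benzylpiperidine naphthamides: D(4) binding, compound 4 estimate

The compounds below may be only part of what the source reports. "The series", "measured", "known", "first", "only" and "open" are said of these compounds alone.

Measured so far:
compound 1 `O=C(NC1CCN(Cc2cccc(Br)c2)CC1)c1cccc2ccccc12` gives 66 nM in an assay on isolated protein for displacement of a labelled ligand from D(4) dopamine receptor (Homo sapiens); a higher number here means a weaker inhibitor, a lower number a stronger inhibitor
compound 2 `O=C(NC1CCN(Cc2cccc(C(F)(F)F)c2)CC1)c1cccc2ccccc12` gives 119 nM in this assay
compound 3 `O=C(NC1CCN(Cc2cccc(C(F)(F)F)c2)CC1)c1ccc2ccccc2c1` gives 103 nM in this assay

Compound 3 sits among the three numbers with its nearest neighbour compound 2 and compound 1 further off, both gaps within the scatter; the three values are not separable on this evidence.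

Compound 4 `Cc1ccccc1CN1CCC(NC(=O)c2ccc3ccccc3c2)CC1` differs from compound 3 by 2-methylphenyl in place of 3-(trifluoromethyl)phenyl on a saturated chain carbon bound to an amine nitrogen in a ring. Of the measured steps only one touches the same part of the core: a 1.8-fold higher number from compound 1 to compound 2 (0.26 log units; within the scatter), a swap of one substituent for another at the same position on the benzyl ring, which did not move the number beyond the scatter. The other step, a 1.2-fold lower number from compound 2 to compound 3 (0.06 log units; within the scatter), concerns the naphthyl side and is uninformative here. Within the data shown here, no measured pair covers a change of substituent position on the benzyl ring, so the step is expected to be no larger than the scatter, without a preferred direction; compound 4 is expected at a 1.1-fold higher number from compound 3 to compound 4 (0.03 log units; within the scatter), i.e. about 110 nM with a range of 40 nM to 320 nM.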

Compound 4, inhibition constant: 26 nM
The estimate for compound 4 lay 4.2-fold (0.63 log units) above the measured number, and the stated range ends above it.
By their numbers in this assay, from the lowest: compound 4; then compounds 1, 3 and 2 (each within the scatter of the next).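

Among these compounds, with 2-methylphenyl in place of 3-(trifluoromethyl)phenyl on a saturated chain carbon bound to an amine nitrogen in a ring, this assay gives a 4.0-fold lower number from compound 3 to compound 4 (0.60 log units; beyond the scatter) and thus shows the first step beyond the scatter. The earlier change on this phenyl ring, a 1.8-fold higher number from compound 1 to compound 2 (0.26 log units; within the scatter), stayed within the scatter, so this position proves able to move the number once the group changes in kind and in placement together. Nothing measured on these compounds bears on why the number falls here.

Among the compounds shown here, the single step changes the substituent and its place on the phenyl ring together, leaving open whether methyl itself, its placement or the loss of trifluoromethyl carries the gain. Also open, from the compounds shown here alone, are the outcome with methoxy or chloro in the same place and whether the 2-methylphenyl gain holds with the naphthalen-1-yl amide.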